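A few compounds are considered here, and "the series" means these few. Any claim that something is new, unique, unknown or untested is made for them only; others in the source may bear on it.

Series on the shared core of compound 1 `COc1ccc2c(=O)c(-c3cc(OC)c(OC)cc3OC)coc2c1`, varied on a saturated chain carbon bound to an oxygen on an aromatic ring. In a functional assay on HUVEC cells (Homo sapiens) for antiproliferative activity, read by MTT assay, with a stated time of 24 h (a higher number here means a weaker inhibitor, a lower number a stronger inhibitor), compound 1 reaches only the limit of the assay, > 10000 nM. Compound 2 `COc1cc(OC)c(-c2coc3cc(OCC(=O)c4cccc(C(F)(F)F)c4)ccc3c2=O)cc1OC` carries (3-(trifluoromethyl)phenyl)carbonyl at that carbon, and in this assay compound 2 also sits at the limit, > 10000 nM. Compound 2 therefore stands at the limit of > 10000 nM in this assay, at which 2 of the 3 values shown sit, with no number of its own. Compound 3 `COc1cc(OC)c(-c2coc3cc(OCc4ccccc4F)ccc3c2=O)cc1OC` carries 2-fluorophenyl there, and in this assay compound 3 gives 4300 nM. The step that the two limits leave unreadable from compound 1 to compound 2 cannot be read. For the measured compounds named here, the steps that bear on compound 4 `COc1cc(OC)c(-c2coc3cc(OCc4ccc(C(F)(F)F)cc4)ccc3c2=O)cc1OC` are an at least 2.3-fold lower number from compound 1 to compound 3 (0.36 log units; beyond the scatter) and an at least 2.3-fold lower number from compound 2 to compound 3 (0.36 log units; beyond the scatter); compound 4 differs from compound 2 by 4-(trifluoromethyl)phenyl in place of (3-(trifluoromethyl)phenyl)carbonyl on a saturated chain carbon bound to an oxygen on an aromatic ring. Both readable steps place a trifluoromethyl-free or fluorine-bearing phenyl directly on that carbon and lower the number beyond the scatter, so a step of like direction and size is expected for the 4-(trifluoromethyl)phenyl, with the risk that only a limit is again reported. Compound 4 is estimated at 4000 nM, between 1500 nM and 12000 nM. That estimate means an expected at least 2.5-fold lower number from compound 2 to compound 4 (0.39 log units; beyond the scatter).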

Compound 4, half-maximal inhibitory concentration: > 10000 nM
Compound 4: a limit, no number; the forecaster's own chance of this, stated with the estimate: 25%; middle value at least 2.5-fold (0.39 log units) from the limit.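

In this assay, 4-(trifluoromethyl)phenyl in place of 2-fluorophenyl on the saturated chain carbon gives an at least 2.3-fold higher number from compound 3 to compound 4 (0.36 log units; beyond the scatter). A phenyl ring on this carbon is therefore not enough on its own, and the gain seen with compound 3 does not carry over to every substituted phenyl placed there. The steps from compound 1 to compound 4 and from compound 2 to compound 4 cannot be read, as both ends of each are limits, and compound 3 remains the only compound with a number of its own: the limit of > 10000 nM in this assay, at which 3 of the 4 values shown sit.

Still open, on these data alone, is whether the number follows the kind of substituent on the phenyl ring or its place on that ring, as the two groups differ in both. An unsubstituted phenyl or a 4-fluorophenyl on the same carbon would separate these two readings.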